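A Nitro for Methyl on the Sulfonyl Ring

The compounds below may be only part of what the source reports. "The series", "measured", "known", "first", "only" and "open" are said of these compounds alone.

Compound 1 `CN1C/C(=C\c2ccncc2)C(=O)/C(=C/c2ccccc2C(F)(F)F)C1`: 3300 nM
Compound 2 `Cc1ccc(S(=O)(=O)N2C/C(=C\c3ccncc3)C(=O)/C(=C/c3ccccc3C(F)(F)F)C2)cc1`: 4640 nM

Both values come from a functional assay on HepG2 cells (Homo sapiens) for cytotoxicity, read by MTT assay, with a stated time of 24 h; on this read-out higher numbers stand for weaker inhibition and lower numbers for stronger inhibition. Among the compounds with values here, compound 2 cannot be told apart from compound 1 on these numbers: the only measured step, a 1.4-fold higher number from compound 1 to compound 2 (0.15 log units; within the scatter), replaces methyl on the ring amine nitrogen with (4-methylphenyl)sulfonyl. Compound 3 `O=C1/C(=C/c2ccncc2)CN(S(=O)(=O)c2ccc([N+](=O)[O-])cc2)C/C1=C\c1ccccc1C(F)(F)F` turns 4-methylphenyl into 4-nitrophenyl: nitro in place of methyl on an aromatic carbon. The nitro group sits on an aromatic carbon, para to a large group. Within the data shown here, no measured step covers this exchange, so the evidence is indirect. Even the much larger exchange on the nitrogen stayed within the scatter, which suggests a small effect here too. The expected change is a 1.2-fold lower number from compound 2 to compound 3 (0.06 log units; within the scatter), so no step beyond the scatter is expected. For compound 3 the estimated value is 4000 nM, with an expected range of 1700 nM to 9000 nM.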

Compound 3, half-maximal inhibitory concentration: 13400 nM
Beside the measured number, compound 3's estimate is 3.4-fold (0.53 log units) below it, outside the stated range (above it).
By their numbers in this assay, from the lowest: compounds 1 and 2 (each within the scatter of the next); then compound 3.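

Changing the far end of the sulfonyl group does register in this assay: nitro in place of methyl on the aromatic carbon gives a 2.9-fold higher number from compound 2 to compound 3 (0.46 log units; beyond the scatter) and a modest step towards weaker inhibition. The earlier pair showed only that a methyl and a (4-methylphenyl)sulfonyl on the ring amine nitrogen could not be told apart, and that does not extend to every sulfonyl group, since (4-nitrophenyl)sulfonyl in place of methyl gives a 4.1-fold higher number from compound 1 to compound 3 (0.61 log units; beyond the scatter) and also lies beyond the scatter. No measurement here offers an explanation for this step.

A single exchange cannot show whether the nitro group is unusual or whether other groups on this aromatic carbon would shift the number as well. As far as these compounds go, an amine or a carboxylic acid there would be informative, and the direction and size of their steps remain open.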